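A few compounds are considered here, and "the series" means these few. Any claim that something is new, unique, unknown or untested is made for them only; others in the source may bear on it.

Compound 1 `CCCc1cn(C/C=C(\C)CCC=C(C)C)nn1` gives 4.5
Compound 2 `CCCc1cn(C/C=C(/C)CCC=C(C)C)nn1` gives 4.05

In a physicochemical assay for lipophilicity, measured as octanol-water partition (a higher number here means a more lipophilic compound, a lower number a more polar compound), compound 1 stands highest of the two. Going by the values given here, the only measured step of a number 0.45 log units lower from compound 1 to compound 2 (beyond the scatter) comes with the fact that compounds 1 and 2 differ only in the configuration as drawn and leaves the propyl untouched, so it is a weak guide here. Compound 3 `COC(=O)c1cn(C/C=C(\C)CCC=C(C)C)nn1` has methoxycarbonyl in place of propyl on an aromatic carbon. Methoxycarbonyl brings hydrogen-bond acceptors, so compound 1 at 4.5 points to a lower number in this assay and a larger fall than that measured step. The expected change is a number 1.30 log units lower from compound 1 to compound 3 (beyond the scatter) in size and direction. Compound 3 is estimated at 3.2 with 2.7 to 3.7 as its expected range.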

Compound 3, partition coefficient: 3.2
Compound 3: the middle estimate sits on the measured number at the digits printed; the measured number falls inside the stated range.
By their numbers in this assay, from the lowest: compound 3; then compound 2; then compound 1.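

In this assay, the aromatic carbon that carries propyl proves sensitive to what sits there: putting methoxycarbonyl in its place gives a number 1.30 log units lower from compound 1 to compound 3 (beyond the scatter). That is a larger step than the one from changing the double-bond configuration, a number 0.45 log units lower from compound 1 to compound 2 (beyond the scatter). Nothing known about these compounds gives a cause for the larger step.

Open, on these data alone, is where a carboxylic acid, an amine or a longer chain at this carbon would fall. Also open, as far as these compounds go, is whether the same swap on compound 2 gives a step of similar size.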